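Swapping Trifluoromethyl for Acetyl: Expected Inhibition in Rats

The source may report more compounds than this note shows. Statements on the series, on what has been measured and on what is new or still open speak of the compounds shown alone.

Compound 1 `CC1CC/C(=N\Nc2ccc(I)cc2)c2ncc(C(=O)O)c(=O)n21`: > 1000 umol/kg
Compound 2 `CC1CC/C(=N\Nc2ccc(C(F)(F)F)cc2)c2ncc(C(=O)O)c(=O)n21`: > 1000 umol/kg

Of the compounds shown here, two have been tested in a functional assay on the whole organism for inhibition, with Rattus norvegicus as the target; on this read-out higher numbers stand for an effect only at larger amounts of compound and lower numbers for an effect already at smaller amounts. Compound 1 `CC1CC/C(=N\Nc2ccc(I)cc2)c2ncc(C(=O)O)c(=O)n21` gives > 1000 umol/kg, which is a limit of this assay rather than a number. Compound 2 `CC1CC/C(=N\Nc2ccc(C(F)(F)F)cc2)c2ncc(C(=O)O)c(=O)n21` gives > 1000 umol/kg, again a limit rather than a number. The step from compound 1 to compound 2, trifluoromethyl in place of iodo on an aromatic carbon, is a step that the two limits leave unreadable from compound 1 to compound 2. Compound 2 therefore stands at the limit, and both values shown sit there (the limit of > 1000 umol/kg in this assay, at which 2 of the 2 values shown sit).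

Compound 3 `CC(=O)c1ccc(N/N=C2\CCC(C)n3c2ncc(C(=O)O)c3=O)cc1` is not yet measured. It differs from compound 2 as follows: acetyl in place of trifluoromethyl on an aromatic carbon. Among the compounds with values here, only one measured step exists, and it is unreadable, so it gives no guide to the size or direction of this change. With both measured compounds at the limit, the most that can be said is that compound 3 is expected to stay near that limit. The expected step from compound 2 to compound 3 is a number no higher from compound 2 to compound 3 (the limit leaves the size open). For compound 3 the estimate in this assay is 1000 umol/kg, with a range from 300 umol/kg to 3000 umol/kg, and most likely only a limit will again be reported.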

Compound 3, dose for 50% inhibition: > 100 umol/kg
Compound 3 ended at the assay's limit (the forecaster's own chance of this, stated with the estimate: 80%); the middle value does not contradict the limit.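

In this assay compound 3 gives > 100 umol/kg, which is a limit and not a number. Within the data shown here, compound 1 and compound 2 also stand at limits, so no step among compound 1, compound 2 and compound 3 can be read. The compounds shown leave open whether iodo, trifluoromethyl or acetyl on the aromatic carbon makes any difference to the dose needed for inhibition.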